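Swapping Fluoro for Amino in Compound 2

This account rests on a few compounds, and the source may have more. Where it says the series, first, only, none or still open, it means among the compounds named here.

Going by the values given here, in a functional assay on A549 cells (Homo sapiens) for inhibition, with a stated time of 48 h, tested at 50 uM (a lower number here means less inhibition of growth, a higher number more inhibition of growth at the concentration tested), compound 1 (`COc1ccccc1/C=C/[C@@](C)(/C=C/c1ccc(O)cc1)CCC=C(C)C`) gives 10%, and compound 2 (`CC(C)=CCC[C@](C)(/C=C/c1ccc(O)cc1)/C=C/c1ccc(F)cc1`) gives 31%, the higher of the two numbers so far. The next molecule, compound 3 (`CC(C)=CCC[C@@](C)(/C=C/c1ccc(N)cc1)/C=C/c1ccc(O)cc1`), keeps the rest of compound 2 but has amino in place of fluoro on an aromatic carbon, turning 4-fluorophenyl into 4-aminophenyl: amino in place of fluoro on an aromatic carbon. Among the compounds with values here, only one measured step bears on this, a number 21 percentage points higher from compound 1 to compound 2 (beyond the scatter). That modest step brought in the 4-fluorophenyl group by replacing 2-methoxyphenyl, so it shows that changing this aryl group can move the number. Within the data shown here, it does not show what amino will do, and no measured compound reveals a direction. The expected result is therefore a number 1 percentage points lower from compound 2 to compound 3 (within the scatter), with no clear shift anticipated. For compound 3, the estimated value is 30%, within an expected range of 12% to 52%.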

Compound 3, percent growth inhibition at one concentration: 57%
Estimate against measurement, compound 3: 27 percentage points below; measured number outside the range, above it.
By their numbers in this assay, from the lowest: compound 1; then compound 2; then compound 3.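

Amino in place of fluoro on this aromatic carbon gives a number 26 percentage points higher from compound 2 to compound 3 (beyond the scatter) in this assay, so changing one heavy atom at this position is enough to move the number beyond the scatter. The earlier step exchanged a whole aryl group, whereas this one leaves the ring in place, and the exchange of 2-methoxyphenyl for 4-aminophenyl gives a number 47 percentage points higher from compound 1 to compound 3 (beyond the scatter), a large step where the exchange for 4-fluorophenyl was modest. No measurement here accounts for the rise.

The compounds shown leave open whether the higher number needs a free amino group, which methylamino, dimethylamino or acetamido on the same aromatic carbon could test. They also leave open whether a carboxylic acid or nitrile there would give a similar number.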